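Cyclopropyl in place of the aryl group: compound 3

This account rests on a few compounds, and the source may have more. Where it says the series, first, only, none or still open, it means among the compounds named here.

Measured in an assay on HEK293 cells for activation of Kir3.1/Kir3.2 (Homo sapiens), read by thallium flux; a higher number here means that more compound is needed for the effect, a lower number that less compound is needed:
compound 1 `Cc1ccc(-c2nnn(CC(=O)Nc3cc(C)nn3C3CCCCC3)n2)cc1`: 111 nM
compound 2 `COc1cccc(-c2nnn(CC(=O)Nc3cc(C)nn3C3CCCCC3)n2)c1`: 117 nM

Among the measured compounds shown here, compound 2 holds the highest of the two numbers so far, but the only step, a 1.1-fold higher number from compound 1 to compound 2 (0.02 log units; within the scatter), lies within the scatter, so the two compounds are not separated. Compound 3 `Cc1cc(NC(=O)Cn2nnc(C3CC3)n2)n(C2CCCCC2)n1` differs from compound 2 by cyclopropyl in place of 3-methoxyphenyl on an aromatic carbon. For the measured compounds named here, the one measured step, a 1.1-fold higher number from compound 1 to compound 2 (0.02 log units; within the scatter), exchanged one six-membered aromatic ring for another and left the number unchanged beyond the scatter; it says nothing about removing that ring altogether. Going by the values given here, no measured pair tests a shift from an aromatic ring to cyclopropyl, so the direction of the step rests on no comparison. As a larger structural change than the one measured, compound 3 is expected to give a higher number in this assay, about 400 nM with a range of 120 nM to 1500 nM. The expected step of a 3.4-fold higher number from compound 2 to compound 3 (0.53 log units; beyond the scatter) is thought to exceed the scatter, with wide uncertainty.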

Compound 3, half-maximal effective concentration: > 3000 nM
Compound 3: a limit, no number; the forecaster's own chance of this, stated with the estimate: 15%; middle value at least 7.5-fold (0.87 log units) from the limit.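

In this assay compound 3 gives > 3000 nM as a limit of the assay and not a number: the limit of > 3000 nM in this assay, at which 1 of the 3 values shown sits.

The earlier exchange between two aryl groups left the two compounds unseparated, whereas replacing the aryl group with cyclopropyl on this aromatic carbon gives large steps in both comparisons: an at least 25-fold higher number from compound 2 to compound 3 (1.40 log units; beyond the scatter) and an at least 27-fold higher number from compound 1 to compound 3 (1.43 log units; beyond the scatter). The position is therefore not indifferent to what it carries, and both compounds with measured numbers keep a six-membered aromatic ring of carbon only there.

The change removes that aromatic ring and also reduces the heavy atoms of the group, so the compounds shown do not separate these two differences. As far as these compounds go, a pyridine ring or a longer alkyl chain at this carbon would bear on that question, and the full size of both steps remains open.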